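A few compounds are considered here, and "the series" means these few. Any claim that something is new, unique, unknown or untested is made for them only; others in the source may bear on it.

Working notes on a small set sharing one core, followed in an ADME assay on cells (Hepatocyte, Rattus norvegicus) for pharmacokinetics, read by LC-MS, with a stated time of 90 min, tested at 1 uM; a lower number here means slower removal, a higher number faster removal of the compound.

Compound 1 `COC(=O)N(CCO)c1c(N)nc(-c2nn(Cc3ccccc3F)c3ncccc23)nc1N` carries a hydroxymethyl on a saturated chain carbon bound to an amide-type nitrogen; in this assay compound 1 gives 61.7 mL/min/kg. Compound 2 `COC(=O)N(Cc1ccccc1F)c1c(N)nc(-c2nn(Cc3ccccc3F)c3ncccc23)nc1N` gives 53.3 mL/min/kg, and compound 3 `COC(=O)N(Cc1cccc(F)c1)c1c(N)nc(-c2nn(Cc3ccccc3F)c3ncccc23)nc1N` gives 53.3 mL/min/kg. Compound 1 thus shows the largest of the three numbers, but the steps of a 1.2-fold lower number from compound 1 to compound 2 (0.06 log units; within the scatter) and a 1.2-fold lower number from compound 1 to compound 3 (0.06 log units; within the scatter) are both within the scatter, as is no change at the digits printed from compound 2 to compound 3 (within the scatter), so the three compounds are not separated here.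

Compound 4 `COC(=O)N(Cc1ccc(F)cc1)c1c(N)nc(-c2nn(Cc3ccccc3F)c3ncccc23)nc1N` is not yet measured. Relative to compound 1 the change is 4-fluorophenyl in place of hydroxymethyl on a saturated chain carbon bound to an amide-type nitrogen.

For the measured compounds named here, the steps that bear on this are the two replacements of the same hydroxymethyl by a fluorophenyl: from compound 1 to compound 2 and from compound 1 to compound 3, each a small lowering within the scatter, and the move from compound 2 to compound 3, which left the number unchanged. Placing the fluorine in the third position is therefore expected to behave like the other two, with a step of a 1.1-fold lower number from compound 1 to compound 4 (0.06 log units; within the scatter) that does not go beyond the scatter. Compound 4 is estimated at 54 mL/min/kg, in the range 35 mL/min/kg to 82 mL/min/kg.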

Compound 4, clearance: 40 mL/min/kg
Estimate against measurement, compound 4: 1.4-fold (0.13 log units) above, and the stated range covers the measured number.
By their numbers in this assay, from the lowest: compounds 4, 2, 3 and 1 (each within the scatter of the next).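

Across the four compounds in this assay, the 4-fluorophenyl gives the largest step yet seen at this place on a saturated chain carbon bound to an amide-type nitrogen, with a 1.5-fold lower number from compound 1 to compound 4 (0.19 log units; within the scatter) as its replacement of hydroxymethyl, and even this step does not leave the scatter. Moving the fluorine also leaves the compounds unseparated, since a 1.3-fold lower number from compound 2 to compound 4 (0.12 log units; within the scatter) and a 1.3-fold lower number from compound 3 to compound 4 (0.12 log units; within the scatter) are both within the scatter, so no preference among the 2-fluorophenyl, 3-fluorophenyl and 4-fluorophenyl groups can be stated. Replacing the 2-hydroxyethyl with a 4-fluorobenzyl therefore extends the earlier picture of a place where these changes produce no resolved difference, and no measurement at hand speaks to what lies behind these small steps.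

As far as these compounds go, whether any group at this place can move the clearance beyond the scatter remains open, as an amine, a carboxylic acid or a longer chain ending in an amine would test a different kind of substituent from those compared here. Also open, from the compounds shown here alone, is what the fluorine contributes, which a plain phenyl on the same chain carbon would address directly.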